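A few compounds are considered here, and "the series" means these few. Any claim that something is new, unique, unknown or untested is made for them only; others in the source may bear on it.

Compound 1 `CCOc1nc(N)nc2ncc(-c3ccc(Cl)c(Cl)c3)nc12`: in a functional assay on cells (T-cell, Homo sapiens) for inhibition (on this read-out lower numbers stand for stronger inhibition and higher numbers for weaker inhibition), compound 1 gives > 10000 nM, which is a limit of the assay and not a number.
Compound 2 `COc1ccc(-c2cnc3nc(N)nc(N4CCN(C(=O)Nc5ccc(C)cc5)CC4)c3n2)cc1OC`: in this assay compound 2 gives 0.8 nM.
Compound 3 `CCOc1nc(N)nc2ncc(-c3ccc(OC)cc3)nc12`: in this assay compound 3 gives > 10000 nM, again a limit of the assay rather than a number.

Compound 2 is thus the only one of the three with a measured number in this assay; the rest of the picture is summed up by the limit of > 10000 nM in this assay, at which 2 of the 3 values shown sit.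

Compound 4 `COc1ccc(-c2cnc3nc(N)nc(N4CCN(C(=O)Nc5ccc(C#N)cc5)CC4)c3n2)cc1OC` has not yet been measured. It differs from compound 2 in a single place: cyano in place of methyl on an aromatic carbon. Among the compounds with values here, no pair of measured compounds shows this kind of swap, so the expectation for compound 4 rests on compound 2 alone. The expected change is small, within the usual scatter, with no clear direction: a 1.3-fold higher number from compound 2 to compound 4 (0.10 log units; within the scatter). Compound 4 is therefore estimated at 1 nM in this assay, with a likely range from 0.3 nM to 4 nM.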

Compound 4, half-maximal inhibitory concentration: 74 nM
Compound 4: the middle estimate sits 74-fold (1.87 log units) below what was measured; measured number outside the range, above it.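

In this assay, the position on the 4-methylphenyl ring of compound 2 proves far from indifferent: cyano in place of methyl gives a 93-fold higher number from compound 2 to compound 4 (1.97 log units; beyond the scatter). One small group exchanged for another at this single place is therefore enough to move the read-out well beyond the scatter, so what sits on this ring carbon matters for inhibition in these cells. Nothing among the measurements shown accounts for a step of this size.

From the compounds shown here alone, with only methyl and cyano compared at this place, it remains open whether the weaker inhibition is particular to the nitrile or would follow from replacing methyl with other groups. A hydrogen, a chlorine, a methoxy group or an amine on this carbon would show how narrowly the position tolerates change.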